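This account rests on a few compounds, and the source may have more. Where it says the series, first, only, none or still open, it means among the compounds named here.

Measured in a functional assay on U-373MG ATCC cells (Homo sapiens) for inhibition, read by colorimetric assay and MTT assay, with a stated time of 72 h; on this read-out higher numbers stand for weaker inhibition and lower numbers for stronger inhibition:

compound 1 `C=CCCCCOc1cc2ccccc2cc1-c1cnc(OCCC=C)n1C`: 27000 nM
compound 2 `C=CCCCCOc1cc2ccccc2cc1-c1cnc(OCCCCC=C)n1C`: 33000 nM
compound 3 `C=CCCOc1ncc(-c2ccccc2OC)n1C`: 16000 nM

Within the first pair the only change is but-3-en-1-yl in place of vinyl on a saturated chain carbon, two bonds along the chain from an oxygen on an aromatic ring. It gives a 1.2-fold higher number from compound 1 to compound 2 (0.09 log units; within the scatter), so the two numbers are not told apart here.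

Compound 3 carries a different core; the difference between the core of compound 3 and the core of compound 1 is not broken down here. In this assay compound 3 gives 16000 nM, which sits within the scatter of compound 1 but beyond it against compound 2.

Compound 4 `C=CCCCCOc1ncc(-c2ccccc2OC)n1C` has not yet been measured. It differs from compound 3 by but-3-en-1-yl in place of vinyl on a saturated chain carbon, two bonds along the chain from an oxygen on an aromatic ring. The place line reads the same word for word as for the first pair, so this is the same change, made on the core of compound 3.

For the measured compounds named here, for compound 4 the expected step is a 1.2-fold higher number from compound 3 to compound 4 (0.07 log units; within the scatter), resting on the one earlier instance, which gave a 1.2-fold higher number from compound 1 to compound 2 (0.09 log units; within the scatter). Since that step lay within the scatter, the expectation is little movement. Compound 4 is therefore expected at about 19000 nM, with a range from 9000 nM to 40000 nM.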

Compound 4, half-maximal inhibitory concentration: 9000 nM
Estimate against measurement, compound 4: 2.1-fold (0.32 log units) above; low and high end bracket the measured number.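

On the core of compound 3, but-3-en-1-yl in place of vinyl gives a 1.8-fold lower number from compound 3 to compound 4 (0.25 log units; within the scatter) in this assay, so the numbers of this pair are not told apart. Set beside the same change on the core of compound 1, the two steps are not told apart either, and nothing separates the two cores in their response to this change: the same change on two cores in this assay, a 1.2-fold higher number (0.09 log units; within the scatter) from compound 1 to compound 2 and a 1.8-fold lower number (0.25 log units; within the scatter) from compound 3 to compound 4, 2.2-fold (0.34 log units) apart, within the scatter of two such steps

For the compounds shown here, this supports carrying the change between these two cores with little expected movement in this assay, but it rests on only two pairs and does not show that the change is without effect on other cores or in other assays.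

The chains shown all carry a double bond, and the longest is hex-5-en-1-yl. As far as these compounds go, whether a saturated hexyl chain, a longer chain, or a chain bearing an amine or a carboxylic acid would give a step beyond the scatter on either core remains open.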